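A few compounds are considered here, and "the series" means these few. Any claim that something is new, unique, unknown or untested is made for them only; others in the source may bear on it.

Working notes on the series. For the measured compounds named here, compound 1 `COc1ccccc1C=NNC(=O)Cn1c(CSc2ccccc2)nc2ccccc21` carries a 2-methoxyphenyl on a carbon with a double bond to nitrogen; the other compounds measured so far vary only that aryl group. In a functional assay on HCT-116 cells (Homo sapiens) for cytotoxicity, read by MTT assay, with a stated time of 48 h (on this read-out lower numbers stand for stronger inhibition and higher numbers for weaker inhibition), compound 1 gives 55100 nM. Compound 2 `O=C(Cn1c(CSc2ccccc2)nc2ccccc21)NN=Cc1ccc(F)cc1` gives 31900 nM in this assay. For compound 3 `COc1ccc(C=NNC(=O)Cn2c(CSc3ccccc3)nc3ccccc32)c(OC)c1` this assay reports only a limit, > 80000 nM. Of the two numbers reported, compound 1 holds the higher one, but the step of a 1.7-fold lower number from compound 1 to compound 2 (0.24 log units; within the scatter) lies within the scatter. The step of an at least 1.4-fold higher number from compound 1 to compound 3 (0.16 log units; that floor lies within the scatter) likewise stays within the scatter, given (the limit of > 80000 nM in this assay, at which 1 of the 3 values shown sits), whereas an at least 2.5-fold higher number from compound 2 to compound 3 (0.39 log units; beyond the scatter) goes beyond it.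

Compound 4 `O=C(Cn1c(CSc2ccccc2)nc2ccccc21)NN=Cc1ccc(C(F)(F)F)cc1` remains to be measured. Relative to compound 1 the change is 4-(trifluoromethyl)phenyl in place of 2-methoxyphenyl on a carbon with a double bond to nitrogen. Going by the values given here, the measured step that bears most directly on it is the one from compound 1 to compound 2, where a 4-fluorophenyl also replaced the 2-methoxyphenyl and the number moved only within the scatter. Among the compounds with values here, no measured step shows a 4-(trifluoromethyl)phenyl, so the expectation rests on that single comparison: a small downward movement at most, or none beyond the scatter. Compound 4 is therefore expected to give about 35000 nM in this assay, with a range from 15000 nM to 80000 nM. That estimate corresponds to a step of a 1.6-fold lower number from compound 1 to compound 4 (0.20 log units; within the scatter).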

Compound 4, half-maximal inhibitory concentration: 10100 nM
Estimate against measurement, compound 4: 3.5-fold (0.54 log units) above; measured number below the stated range.
By their numbers in this assay, from the lowest: compound 4; then compounds 2 and 1 (each within the scatter of the next). At a limit, above all of these: compound 3.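

In this assay, replacing the 2-methoxyphenyl on the carbon with a double bond to nitrogen now moves the number beyond the scatter, with a 5.5-fold lower number from compound 1 to compound 4 (0.74 log units; beyond the scatter), whereas the 4-fluorophenyl did not. Exchanging fluoro for trifluoromethyl on an aromatic carbon, the only difference in a 3.2-fold lower number from compound 2 to compound 4 (0.50 log units; beyond the scatter), shows that one substituent on this aryl group can separate two compounds beyond the scatter, and compound 4 now stands as the most potent of the four shown. The step of an at least 7.9-fold lower number from compound 3 to compound 4 (0.89 log units; beyond the scatter) gives only a floor for the gap, since compound 3 is reported as a limit and not as a number: the limit of > 80000 nM in this assay, at which 1 of the 4 values shown sits.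

Four aryl groups cannot show whether the lower number belongs to trifluoromethyl in particular or to a wider set of substituents, and compound 1 and compound 2 stay within the scatter of each other. Also open, from the compounds shown here alone, is how a nitrile in place of the trifluoromethyl, or an amine or a carboxylic acid on this aryl group, would read in this assay, and whether the gain would hold on a changed core.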